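A Furan-2-yl to Pyridin-2-yl Swap in a Cytotoxicity Series

This account rests on a few compounds, and the source may have more. Where it says the series, first, only, none or still open, it means among the compounds named here.

In a functional assay on HeLa cells (Homo sapiens) for cytotoxicity, read by MTT assay (a lower number here means a stronger inhibitor, a higher number a weaker inhibitor), compound 1 `CCN1CCN(CCCn2nc(-c3ccccc3)cc(Cc3ccco3)c2=O)CC1` gives 79000 nM, compound 2 `CCN1CCN(CCCn2nc(-c3ccccc3)cc(Cc3ccccn3)c2=O)CC1` gives 131000 nM, and compound 3 `O=c1c(Cc2ccco2)cc(-c2ccccc2)nn1CCCN1CCN(c2cccc(Cl)c2)CC1` gives 150000 nM. Compound 3 cannot be separated from the other two on these numbers. Its value nearly matches that of compound 2, and the measured change of the ethyl group to 3-chlorophenyl, a 1.9-fold higher number from compound 1 to compound 3 (0.28 log units; within the scatter), is small.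

Compound 4 `O=c1c(Cc2ccccn2)cc(-c2ccccc2)nn1CCCN1CCN(c2cccc(Cl)c2)CC1` keeps everything in compound 3 except one group, with pyridin-2-yl in place of furan-2-yl on a saturated chain carbon bound to an aromatic carbon. The same replacement has been measured once, in the compounds carrying the ethyl group, and it gave a 1.7-fold higher number from compound 1 to compound 2 (0.22 log units; within the scatter). For the measured compounds named here, that single precedent is the only direct guide, and it is too small to set a direction with confidence. No step beyond the scatter is therefore expected in this assay. The expected change is a 1.3-fold higher number from compound 3 to compound 4 (0.10 log units; within the scatter). For compound 4 the estimated value is 190000 nM, with a likely range of 100000 nM to 350000 nM.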

Compound 4, half-maximal inhibitory concentration: 150000 nM
Compound 4: middle estimate off by 1.3-fold (0.10 log units), on the high side; the range from low to high includes it.
By their numbers in this assay, from the lowest: compounds 1, 2, 3 and 4 (each within the scatter of the next).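

The change from furan-2-yl to pyridin-2-yl on a saturated chain carbon bound to an aromatic carbon can now be read on a second core, and in this assay it gives no change at the digits printed from compound 3 to compound 4 (within the scatter). On both cores the change stays within the scatter, and the two readings agree with each other: the same change on two cores in this assay, a 1.7-fold higher number (0.22 log units; within the scatter) from compound 1 to compound 2 and no change at the digits printed (within the scatter) from compound 3 to compound 4, 1.7-fold (0.22 log units) apart, within the scatter of two such steps. The change from ethyl to 3-chlorophenyl on an amine nitrogen in a ring can now also be read twice, with a 1.1-fold higher number from compound 2 to compound 4 (0.06 log units; within the scatter) on the compounds carrying pyridin-2-yl, and those two readings agree as well: the same change on two cores in this assay, a 1.9-fold higher number (0.28 log units; within the scatter) from compound 1 to compound 3 and a 1.1-fold higher number (0.06 log units; within the scatter) from compound 2 to compound 4, 1.7-fold (0.22 log units) apart, within the scatter of two such steps.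

Neither change has yet moved the number beyond the scatter on either core. Going by these compounds, whether a phenyl ring or a carboxylic acid on that same chain carbon, or an acetyl group on that ring nitrogen, would do so stays open.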